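A few compounds are considered here, and "the series" means these few. Any claim that something is new, unique, unknown or untested is made for them only; others in the source may bear on it.

Compound 1, `COc1cc(Cl)cc(-c2nn(-c3cccc(NC(=O)Nc4ccc(Cl)c(C(F)(F)F)c4)c3)cc2-c2ccncc2)c1`: -28%
Compound 2, `COc1cc(Cl)cc(-c2nn(-c3cccc(NC(=O)Nc4cc(C(F)(F)F)cc(C(F)(F)F)c4)c3)cc2-c2ccncc2)c1`: -34%

Of the compounds shown here, two have been tested in a functional assay on MOLT-4 cells (Homo sapiens) for inhibition, read by sulforhodamine B assay, with a stated time of 48 h, tested at 100 uM; on this read-out higher numbers stand for a weaker effect at the one concentration tested and lower numbers for a stronger effect. Compound 1 gives -28%, and compound 2 gives -34%. Compound 1 has the higher of the two numbers, but the gap to compound 2 lies within the scatter, so the two cannot be told apart on this read-out.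

Compound 3, `COc1cc(Cl)cc(-c2nn(-c3cccc(NC(=O)c4cccc(C(F)(F)F)c4)c3)cc2-c2ccncc2)c1`, has not yet been measured. It differs from compound 1 in one place: 3-(trifluoromethyl)phenyl in place of (4-chloro-3-(trifluoromethyl)phenyl)amino on a carbonyl carbon. The change sits on a carbonyl carbon whose other neighbour is an amide-type nitrogen, and the group that leaves carries the only hydrogen-bond donor of the exchanged pieces.

Going by the values given here, no measured pair in this set shows what such a change does in this assay, so there is nothing to lean on beyond the two values and the structures. The expected step is a number 4 percentage points higher from compound 1 to compound 3 (within the scatter), which would not reach beyond the scatter. The estimate for compound 3 is -24%, within a range from -48% to 2%.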

Compound 3, a percentage reported as activity, at one concentration (the size of the read-out at that concentration, not a potency): 27%
Beside the measured number, compound 3's estimate is 51 percentage points below it; measured number outside the range, above it.
By their numbers in this assay, from the lowest: compounds 2 and 1 (each within the scatter of the next); then compound 3.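

In this assay, the exchange on this carbonyl carbon gives a number 55 percentage points higher from compound 1 to compound 3 (beyond the scatter), which means a clearly weaker effect at the one concentration tested, so this position is far from indifferent to what sits on it. Both earlier compounds carry an amino nitrogen on this carbonyl carbon and differ only in the substituents of the outer aromatic ring, so they could not show what happens when that nitrogen goes, with its hydrogen-bond donor, and the aromatic ring is joined directly to the carbonyl carbon instead. Nothing measured for these compounds explains why the effect weakens so much.

The change also removes a chlorine along with the nitrogen, so the compounds shown leave open how much of the step belongs to each of the two. A (3-(trifluoromethyl)phenyl)amino group on the same carbonyl carbon would keep the nitrogen and lack the chlorine, and its value would divide the step into those two parts.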